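Hydroxy removal in the amino series

The source may hold more compounds than are shown below. What is called first, only, known or untested is meant among the compounds shown, and "the series" means these compounds.

- compound 1 `COc1cccc([C@@H]2[C@H](Oc3ccccc3)C(=O)N2c2cc(OC)c(OC)c(OC)c2)c1`: 171000 nM
- compound 2 `COc1cc(N2C(=O)[C@@H](Oc3ccccc3)[C@H]2c2cc(N)c(OC)c(O)c2)cc(OC)c1OC`: 8800 nM

In a functional assay on MCF7 cells (Homo sapiens) for antiproliferative activity, read by MTT assay, with stated times of 24 h and 72 h (a higher number here means a weaker inhibitor, a lower number a stronger inhibitor), compound 2 has the lower of the two values, 8800 nM. Compound 3 `COc1ccc([C@@H]2[C@H](Oc3ccccc3)C(=O)N2c2cc(OC)c(OC)c(OC)c2)cc1N` carries hydrogen in place of hydroxy on an aromatic carbon, ortho to a methoxy group and meta to an amino group (hydrogen in place of hydroxy on an aromatic carbon). Going by the values given here, only one measured step bears on this change: a 19-fold lower number from compound 1 to compound 2 (1.29 log units; beyond the scatter). It is large, but it replaced a whole group on a saturated ring carbon, so the data do not isolate the hydroxy. Compound 3 retains the amino group and loses only the hydroxy, so a modest rise is expected in this assay, recovering a small part of that step. The expected change is a 2.3-fold higher number from compound 2 to compound 3 (0.36 log units; beyond the scatter). For compound 3 the estimated value is 20000 nM, with an expected range of 4000 nM to 90000 nM.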

Compound 3, half-maximal inhibitory concentration: 12200 nM
Compound 3: the middle estimate sits 1.6-fold (0.21 log units) above what was measured, and the stated range covers the measured number.
By their numbers in this assay, from the lowest: compounds 2 and 3 (each within the scatter of the next); then compound 1.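

In this assay, hydrogen in place of hydroxy on this aromatic carbon, ortho to a methoxy group, leaves the number within the scatter (a 1.4-fold higher number from compound 2 to compound 3 (0.14 log units; within the scatter)), so the hydroxy is not required for the micromolar-range activity of compound 2 in this assay. A large step also survives without any hydroxy (a 14-fold lower number from compound 1 to compound 3 (1.15 log units; beyond the scatter)), with 3-amino-4-methoxyphenyl in place of 3-methoxyphenyl, although that change alters more than the amino group alone.

The shares of the amino group and of the methoxy placement in that step remain unseparated. Also open, going by these compounds, is whether an acetamide or a fluorine at the amino position would keep the value, and whether a methoxy or a fluorine in place of the hydroxy would behave like hydrogen. No supporting measurement bears on why these steps differ in size.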